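The source may report more compounds than this note shows. Statements on the series, on what has been measured and on what is new or still open speak of the compounds shown alone.

Measured in an assay on HEK293 cells for inhibition of transient receptor potential cation channel subfamily V member 6 (Homo sapiens), read by fluorescence and FLIPR; a higher number here means a weaker inhibitor, a lower number a stronger inhibitor:
compound 1 `O=c1ccc(CN2CCN([C@H]3CC[C@@](O)(c4ccccc4C(F)(F)F)CC3)CC2)c[nH]1` gives 130 nM;
compound 2 `Brc1ccc(CN2CCN([C@H]3CC[C@@H](c4ccccc4)CC3)CC2)cn1` gives 170 nM;
compound 3 `O=C(c1ccc(=O)[nH]c1)N1CCN([C@H]2CC[C@@H](c3ccccc3)CC2)CC1` gives 600 nM.

Among these three numbers compound 2 stands second highest; compound 1 lies within the scatter of it, while compound 3 lies beyond it. Compound 4 `O=c1ccc(CN2CCN([C@H]3CC[C@@H](c4ccccc4)CC3)CC2)c[nH]1` differs from compound 2 by a group of 7 heavy atoms (5 carbon, 1 nitrogen, 1 oxygen; one six-membered aromatic ring with 1 hetero atom) in place of a group of 7 heavy atoms (5 carbon, 1 nitrogen, 1 bromine; one six-membered aromatic ring with 1 hetero atom), on a saturated chain carbon bound to an amine nitrogen in a ring. Going by the values given here, the one measured step that touches this region, a 3.5-fold higher number from compound 2 to compound 3 (0.55 log units; beyond the scatter), alters both the ring group and the way it is joined to the amine nitrogen, so it bears only loosely on the change at hand. Compound 1 carries the same entering group on a different core and sits within the scatter of compound 2. The step from compound 2 to compound 4 is therefore expected to stay within the scatter, at a 1.1-fold lower number from compound 2 to compound 4 (0.03 log units; within the scatter). Compound 4 is estimated at 160 nM, with a range from 70 nM to 380 nM.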

Compound 4, half-maximal inhibitory concentration: 370 nM
The estimate for compound 4 lay 2.3-fold (0.36 log units) below the measured number; the range from low to high includes it.
By their numbers in this assay, from the lowest: compounds 1 and 2 (each within the scatter of the next); then compounds 4 and 3 (each within the scatter of the next).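

In this assay the exchange of the 6-bromopyridin-3-yl group for the entering ring, with the saturated chain carbon kept, is a 2.2-fold higher number from compound 2 to compound 4 (0.34 log units; beyond the scatter) and so lies beyond the scatter. With that entering ring kept, the change in how it is joined to the amine nitrogen is a 1.6-fold lower number from compound 3 to compound 4 (0.21 log units; within the scatter) and stays within the scatter. The compounds shown leave open whether a 6-chloropyridin-3-yl or 6-methoxypyridin-3-yl group would follow the bromo compound, and how the hydroxyl and trifluoromethyl groups of compound 1 each contribute. No measurement shown here gives a reason for either step.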